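This account rests on a few compounds, and the source may have more. Where it says the series, first, only, none or still open, it means among the compounds named here.

Measured so far in a functional assay on PC-12 cells (Rattus norvegicus) for cytotoxicity, read by MTT assay, with stated times of 2 h and 24 h, tested at 5 uM; on this read-out lower numbers stand for a weaker effect and higher numbers for a stronger effect at the one concentration tested:
- compound 1 `CC(C)(C)c1ccc(-n2nc(-c3ccc(C(F)(F)F)cc3O)nc2-c2ccccc2O)cc1`: 77.8%
- compound 2 `Oc1cc(C(F)(F)F)ccc1-c1nc(-c2ccccc2O)n(-c2ccc(I)cc2)n1`: 94.4%
- compound 3 `Oc1cc(C(F)(F)F)ccc1-c1nc(-c2ccccc2O)n(-c2ccccc2Cl)n1`: 90.6%

Compound 3 stands second highest of the three numbers. Its nearest neighbour is compound 2, and the step of a number 3.8 percentage points lower from compound 2 to compound 3 (within the scatter) falls within the scatter, so the two values cannot be ordered. The furthest is compound 1, and the step of a number 12.8 percentage points higher from compound 1 to compound 3 (beyond the scatter) lies beyond the scatter.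

Compound 4 `Cc1cc(C)cc(-n2nc(-c3ccc(C(F)(F)F)cc3O)nc2-c2ccccc2O)c1` has not yet been measured. It differs from compound 3 in one place: 3,5-dimethylphenyl in place of 2-chlorophenyl on an aromatic nitrogen

Within the data shown here, two measured steps touch the group on this aromatic nitrogen. The step of a number 16.6 percentage points higher from compound 1 to compound 2 (beyond the scatter) was modest, and the step of a number 3.8 percentage points lower from compound 2 to compound 3 (within the scatter) was within the scatter. Among the measured compounds shown here, no measured step carries a 3,5-dimethylphenyl group, so the direction of the move from compound 3 to compound 4 is not fixed by the data. Given that two of the three measured aryl groups gave values close together, compound 4 is expected to give a step of a number 4.6 percentage points lower from compound 3 to compound 4 (within the scatter), within the scatter. The estimate for compound 4 in this assay is 86%, with a range from 74% to 96%.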

Compound 4, a percentage reported as activity, at one concentration (the size of the read-out at that concentration, not a potency): 102%
The estimate for compound 4 lay 16 percentage points below the measured number; measured number above the stated range.
By their numbers in this assay, from the lowest: compound 1; then compounds 3, 2 and 4 (each within the scatter of the next, the first and the last beyond it).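

In this assay the aryl group on this aromatic nitrogen now separates compounds beyond 4-(tert-butyl)phenyl alone: the two halogen-bearing compounds could not be ordered, yet 3,5-dimethylphenyl gives a number 11.4 percentage points higher from compound 3 to compound 4 (beyond the scatter) and so stands apart from 2-chlorophenyl. Against 4-iodophenyl it gives a number 7.6 percentage points higher from compound 2 to compound 4 (within the scatter) and against 4-(tert-butyl)phenyl it gives a number 24.2 percentage points higher from compound 1 to compound 4 (beyond the scatter) so, with compound 1 as the exception, a phenyl bearing only carbon substituents can match compound 2 without a halogen. Nothing available explains these steps.

Open, as far as these compounds go, is whether a plain phenyl, or a phenyl bearing an amine or a carboxylic acid, on this nitrogen would stay level with compound 4 or fall towards compound 1. Also open, from the compounds shown here alone, is whether these steps would hold at other concentrations, since each compound is read at only one.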